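A few compounds are considered here, and "the series" means these few. Any claim that something is new, unique, unknown or untested is made for them only; others in the source may bear on it.

Measured compounds:
compound 1, `C=C1C[C@]23C[C@@]1(O)CC[C@H]2c1cc(Br)c(O)c(C)c1[C@@H]3Cn1cc(-c2ccccc2)nn1`, > 20000 nM
compound 2, `C=C1C[C@]23C[C@@]1(O)CC[C@H]2c1cc(Br)c(O)c(C)c1[C@@H]3Cn1cc(-c2ccc(C(F)(F)F)cc2)nn1`, 9280 nM
compound 3, `C=C1C[C@]23C[C@@]1(O)CC[C@H]2c1ccc(OS(=O)(=O)c2ccc(C)cc2)c(C)c1[C@@H]3Cn1cc(-c2ccccc2)nn1`, > 20000 nM

The three compounds were tested in a functional assay on A549 cells (Homo sapiens) for cytotoxicity, read by MTT assay, with a stated time of 4 days; on this read-out higher numbers stand for weaker inhibition and lower numbers for stronger inhibition. Compound 1 gives > 20000 nM, which is a limit of this assay rather than a number. Compound 2 carries trifluoromethyl in place of hydrogen on an aromatic carbon relative to compound 1, and in this assay compound 2 gives 9280 nM. The step of an at least 2.1-fold lower number from compound 1 to compound 2 (0.33 log units; beyond the scatter) is therefore known only as a bound, which rests on (the limit of > 20000 nM in this assay, at which 2 of the 3 values shown sit). Compound 3 gives > 20000 nM, again a limit of this assay. The difference between the core of compound 3 and the core of compound 1 is not broken down here.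

Compound 4, `C=C1C[C@]23C[C@@]1(O)CC[C@H]2c1ccc(OS(=O)(=O)c2ccc(C)cc2)c(C)c1[C@@H]3Cn1cc(-c2ccc(C(F)(F)F)cc2)nn1`, has not yet been measured. It differs from compound 3 by trifluoromethyl in place of hydrogen on an aromatic carbon, the same change as that made from compound 1 to compound 2, at the same place on the ring. The step from compound 3 to compound 4 is expected to resemble the earlier one, that is an at least 1.6-fold lower number from compound 3 to compound 4 (0.22 log units; that floor lies within the scatter), an expectation that rests on an at least 2.1-fold lower number from compound 1 to compound 2 (0.33 log units; beyond the scatter) together with the fact that compound 3, like compound 1, sits at the limit of > 20000 nM in this assay, at which 2 of the 3 values shown sit. On that basis compound 4 is estimated at 12000 nM in this assay, with a real chance that only a limit is reported again.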

Compound 4, half-maximal inhibitory concentration: > 20000 nM
Compound 4: a limit, no number (the forecaster's own chance of this, stated with the estimate: 45%); at least 1.6-fold (0.22 log units) between middle value and limit.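

In this assay compound 4 gives > 20000 nM, a limit and not a number. Compound 3 also stands at a limit, so no step from compound 3 to compound 4 can be read: the limit of > 20000 nM in this assay, at which 3 of the 4 values shown sit.

The compounds shown leave open whether trifluoromethyl in place of hydrogen does anything on the core of compound 3 that compares with the step seen on the core of compound 1.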